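The source may report more compounds than this note shows. Statements on the series, on what has been measured and on what is new or still open speak of the compounds shown alone.

Measured in a functional assay on A549 cells (Homo sapiens) for cytotoxicity, read by MTT assay; a lower number here means a stronger inhibitor, a higher number a weaker inhibitor:

Compound 1 `CC(C)C[C@H](NC(=S)NCc1ccccc1)c1nc2ccccc2[nH]1`: 75700 nM
Compound 2 `CC(C)C[C@H](NC(=S)Nc1ccccc1)c1nc2ccccc2[nH]1`: 28600 nM
Compound 3 `CC(C)[C@@H](NC(=S)Nc1cc(C(F)(F)F)cc(C(F)(F)F)c1)c1nc2ccccc2[nH]1`: 22400 nM

Compound 1 has the highest number of these three, which makes it the weakest inhibitor of the set. Its nearest neighbour is compound 2, at a 2.6-fold lower number from compound 1 to compound 2 (0.42 log units; beyond the scatter).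

The next compound, compound 4 `C[C@H](NC(=S)NCc1ccccc1)c1nc2ccccc2[nH]1`, has not yet been measured. It changes the chain of compound 1: hydrogen in place of isopropyl on a saturated chain carbon, two bonds along the chain from an amide-type nitrogen and an aromatic carbon. Cut one bond further out, the same change reads isobutyl to methyl.

The measured data offer little direct guidance. Among the measured compounds shown here, the single measured step, a 2.6-fold lower number from compound 1 to compound 2 (0.42 log units; beyond the scatter), has phenyl in place of benzyl on an amide-type nitrogen, which is a different place from this change. Compound 3, at 22400 nM in this assay, differs from compound 1 in more than one place, so its value cannot be read as the effect of the chain alone. For the measured compounds named here, no measured pair isolates this chain. The expectation is therefore only a small move towards a higher number, not clearly beyond the scatter, and the uncertainty is wide. The expected change is a 1.3-fold higher number from compound 1 to compound 4 (0.12 log units; within the scatter) in this assay. Compound 4 is estimated at 100000 nM (expected range 45000 nM to 220000 nM) in this assay.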

Compound 4, half-maximal inhibitory concentration: "not active" (no number reported)
Compound 4 has no reported number here; the estimate stays without a comparison.
By their numbers in this assay, from the lowest: compounds 3 and 2 (each within the scatter of the next); then compound 1.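

In this assay, among the compounds shown here, compound 4 is reported as "not active" with no number, so no step from compound 1 to compound 4 can be read. Nothing available here offers an explanation for this result. The compounds shown leave open how far the change from isobutyl to methyl shifts the number.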